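The source may report more compounds than this note shows. Statements on the series, on what has been measured and on what is new or still open speak of the compounds shown alone.

Measured in a functional assay on MCF7 cells (Homo sapiens) for cytotoxicity, read by MTT assay, with a stated time of 24 h; on this read-out lower numbers stand for stronger inhibition and higher numbers for weaker inhibition:
- Compound 1 `O=Cc1cc2ccccc2n(Cc2ccccc2)c1=O`: 31900 nM
- Compound 2 `C#CCn1c(=O)c(/C=C/C(=O)/C=C(O)/C=C/c2ccc(O)c(OC)c2)cc2cc(OC)ccc21`: > 100000 nM (a limit)

As far as these compounds go, for compound 2, > 100000 nM is a limit of this assay and not a number, so its exact standing is unknown. Compound 3 `C#CCn1c(=O)c(/C=C/C(=O)/C=C(O)/C=C/c2ccc(O)c(OC)c2)cc2cc(F)ccc21` matches compound 2 except for one substituent, with fluoro in place of methoxy on an aromatic carbon. For the measured compounds named here, no measured pair shows the effect of this swap, so no change beyond the usual scatter is expected. The expected change is an at least 1.4-fold lower number from compound 2 to compound 3 (0.15 log units; that floor lies within the scatter). Compound 3 may also yield only a limit. Compound 3 is estimated at 70000 nM, within an expected range of 25000 nM to 100000 nM.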

Compound 3, half-maximal inhibitory concentration: 25000 nM
Compound 3: middle estimate off by 2.8-fold (0.45 log units), on the high side; the measured number falls inside the stated range.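

In this assay the swap of methoxy for fluoro on this aromatic carbon brings an at least 4.0-fold lower number from compound 2 to compound 3 (0.60 log units; beyond the scatter) and so gives the first measured sign that this position matters. Compound 3 yields an actual number, so the change moves the series from a limit into the measurable range. The step is only a floor, because compound 2 carries a limit and not a number: the limit of > 100000 nM in this assay, at which 1 of the 3 values shown sits.

As far as these compounds go, what stays open is how other groups at this place would compare, such as chloro, an amine or a carboxylic acid. The compounds shown also leave open whether the same swap would act alike on a different core.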